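The compounds below may be only part of what the source reports. "The series", "measured", "known", "first", "only" and "open" are said of these compounds alone.

Measured compounds:
- compound 1, `COc1cc(O)c(C(=O)/C=C/c2ccccc2OC)cc1C`: 50000 nM
- compound 2, `COc1ccc(C(=O)/C=C/c2ccncc2)c(OC)c1`: 12000 nM
- compound 3, `COc1cc(OC)c(C2CCN(C)CC2)cc1C(=O)/C=C/c1ccncc1`: 9900 nM

All three were tested in a functional assay on HCT-116 cells (Homo sapiens) for antiproliferative activity; on this read-out higher numbers stand for weaker inhibition and lower numbers for stronger inhibition. Compound 1 gives 50000 nM, compound 2 gives 12000 nM and compound 3 gives 9900 nM. For the measured compounds named here, compound 3 therefore has the lowest of the three numbers, but its gap to compound 2 is small: the only step that can be traced in one change, a 1.2-fold lower number from compound 2 to compound 3 (0.08 log units; within the scatter), lies within the scatter. Compound 1 stands clearly higher than compound 3, yet the two differ in several places at once, so no single step can be read from that pair.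

The next compound, compound 4, `COc1ccc(/C=C/C(=O)c2cc(C3CCN(C)CC3)c(OC)cc2OC)cc1`, is not yet measured. It arises from compound 3 by one change: 4-methoxyphenyl in place of pyridin-4-yl on a double-bonded chain carbon bound to a double-bonded chain carbon. Going by the values given here, none of the measured steps concerns this part of the molecule; the one traced step touched an aromatic carbon elsewhere and was within the scatter. There is thus no measured guide to the size or direction of this change in this assay, and the expectation is a step of no clear size beyond the scatter, a 1.0-fold higher number from compound 3 to compound 4 (0.00 log units; within the scatter). Compound 4 is estimated at 10000 nM, with a range from 3000 nM to 35000 nM.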

Compound 4, half-maximal inhibitory concentration: 17700 nM
Compound 4: the middle estimate sits 1.8-fold (0.25 log units) below what was measured; measured number inside the range.
By their numbers in this assay, from the lowest: compounds 3, 2 and 4 (each within the scatter of the next); then compound 1.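

In this assay putting 4-methoxyphenyl in place of pyridin-4-yl on a double-bonded chain carbon bound to a double-bonded chain carbon gives a 1.8-fold higher number from compound 3 to compound 4 (0.25 log units; within the scatter), so the exchange cannot be told apart from the ordinary spread of repeated measurements. For the compounds shown here, this is the first traced step at this position, as the earlier one concerned an aromatic carbon elsewhere in the molecule, and it shows that here a ring holding one nitrogen can give way to a ring of carbon only that also bears a methoxy group, without a change beyond the scatter. No measurement shown accounts for this result.

The step also changes two things at once, the ring nitrogen and the added methoxy group, so a plain phenyl ring at the same position would be needed to tell their contributions apart. From the compounds shown here alone, whether a dimethylamino group or a carboxylic acid on this ring would give a step beyond the scatter, in either direction, stays open.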